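The source may report more compounds than this note shows. Statements on the series, on what has been measured and on what is new or still open speak of the compounds shown alone.

Working notes on the cytotoxicity series.

The three measured compounds share one core and differ only in the group on the amine nitrogen. Compound 1 `Cc1cn([C@@H]2O[C@H](CO[Si](C)(C)C(C)(C)C)[C@@]3(OS(=O)(=O)C=C3NC(=O)c3ccccc3)[C@H]2O[Si](C)(C)C(C)(C)C)c(=O)n(C)c1=O` carries a benzoyl there; in a functional assay on HEL cells (Homo sapiens) for cytotoxicity, read by microscopy (a higher number here means that more compound is tolerated, a lower number that less compound is tolerated), compound 1 returns only a limit, >= 3200 nM, so no number is known for it (the limit of >= 3200 nM in this assay, at which 1 of the 3 values shown sits). Compound 2 `Cc1cn([C@@H]2O[C@H](CO[Si](C)(C)C(C)(C)C)[C@@]3(OS(=O)(=O)C=C3NCCC(=O)O)[C@H]2O[Si](C)(C)C(C)(C)C)c(=O)n(C)c1=O` carries a 2-carboxyethyl and in this assay gives 80000 nM, the lowest of the two readable numbers. Compound 3 `Cc1cn([C@@H]2O[C@H](CO[Si](C)(C)C(C)(C)C)[C@@]3(OS(=O)(=O)C=C3NCC(=O)O)[C@H]2O[Si](C)(C)C(C)(C)C)c(=O)n(C)c1=O` carries a carboxymethyl and gives 300000 nM. For the measured compounds named here, the only readable step, carboxy in place of carboxymethyl on a saturated chain carbon bound to an amine nitrogen, gives a 3.8-fold higher number from compound 2 to compound 3 (0.57 log units; beyond the scatter); the steps from compound 1 cannot be sized.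

Compound 4 `Cc1cn([C@@H]2O[C@H](CO[Si](C)(C)C(C)(C)C)[C@@]3(OS(=O)(=O)C=C3NCC(N)=O)[C@H]2O[Si](C)(C)C(C)(C)C)c(=O)n(C)c1=O` is not yet measured. It differs from compound 2 as follows: carbamoyl in place of carboxymethyl on a saturated chain carbon bound to an amine nitrogen. Read one bond further out, this is 2-carboxyethyl to carbamoylmethyl, so compound 4 shares the shorter chain of compound 3 but ends in carbamoyl rather than carboxy. The one measured step suggests that shortening the chain raises the number; what the carbamoyl itself does is not shown by any pair here. The estimate for compound 4 is therefore a modest rise, a 1.9-fold higher number from compound 2 to compound 4 (0.27 log units; within the scatter), leaving compound 4 at an expected 150000 nM with a range of 40000 nM to 500000 nM.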

Compound 4, minimum cytotoxic concentration: 16000 nM
Beside the measured number, compound 4's estimate is 9.4-fold (0.97 log units) above it; measured number below the stated range.
By their numbers in this assay, from the lowest: compound 4; then compound 2; then compound 3.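

For the compounds shown here, at the shorter chain, the end group carries more weight than the earlier compounds could show: in this assay, amino in place of hydroxy on a carbonyl carbon gives a 19-fold lower number from compound 3 to compound 4 (1.27 log units; beyond the scatter). The change from 2-carboxyethyl to carbamoylmethyl gives a 5.0-fold lower number from compound 2 to compound 4 (0.70 log units; beyond the scatter), so shortening the chain does not by itself go with a higher number, and the pair of carboxylic acids alone did not show the whole picture, with compound 3 above compound 2 and compound 4 below it. No step from compound 1, including the one to compound 4, can be read, as compound 1 returns only a limit: the limit of >= 3200 nM in this assay, at which 1 of the 4 values shown sits.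

On these data alone, what remains open is whether the lower number is specific to the carbamoyl or would also appear with another end group on the shorter chain, such as a methyl ester or an amine. Also open, as far as these compounds go, is how chain length acts when the end group is a carbamoyl, which a longer chain such as 2-carbamoylethyl would bear on directly.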